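Solubility of a quinolinyl azetidine ether series

This account rests on a few compounds, and the source may have more. Where it says the series, first, only, none or still open, it means among the compounds named here.

Compounds 1 and 2 share a quinolinyl azetidine ether core and differ in the saturated amine that hangs on the diazine or pyridine ring. Compound 1 `OCC1CCN(c2cccnc2OC2CN(c3ccc4ccccc4n3)C2)CC1` and compound 2 `OCC1CCN(c2nccnc2OC2CN(c3ccc4ccccc4n3)C2)C1` were both measured in a physicochemical assay for solubility, in phosphate buffer, at pH 7.4; on this read-out higher numbers stand for higher solubility and lower numbers for lower solubility. Compound 1 gives 189000 nM in this assay, and compound 2 gives 167000 nM. These two numbers lie within the usual scatter of each other, so no ranking between compound 1 and compound 2 can be read from them.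

Compound 3 `c1ccc2nc(N3CC(Oc4nccnc4-c4ccncc4)C3)ccc2c1` has not yet been measured in this assay. It differs from compound 2 in one place: pyridin-4-yl in place of 3-(hydroxymethyl)pyrrolidin-1-yl on an aromatic carbon. For the measured compounds named here, with no measured pair showing this kind of change, the only footing is the loss of the hydrogen-bond donor and of the non-aromatic ring counted in that difference. Compound 3 is therefore expected to fall clearly in this assay, with a drop well beyond the scatter, an 8.4-fold lower number from compound 2 to compound 3 (0.92 log units; beyond the scatter). The estimate for compound 3 in this assay is 20000 nM, with a range from 3000 nM to 80000 nM.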

Compound 3, solubility: 56000 nM
Compound 3: middle estimate off by 2.8-fold (0.45 log units), on the low side; the measured number falls inside the stated range.
By their numbers in this assay, from the lowest: compound 3; then compounds 2 and 1 (each within the scatter of the next).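

At the carbon of the ring with 2 nitrogen, two atoms from the ring nitrogen, pyridin-4-yl in place of 3-(hydroxymethyl)pyrrolidin-1-yl gives, in this assay, a 3.0-fold lower number from compound 2 to compound 3 (0.47 log units; beyond the scatter). For the compounds shown here, this is the first step that can be read for a change in one place, and it shows that this exchange lowers the number beyond the scatter, though the step is only modest. No measurement shown here accounts for the size of this step.

The exchange takes away the hydroxymethyl group and the non-aromatic ring together and brings in an aromatic ring, so this single step cannot show how much of the drop belongs to each of these differences. Plain pyrrolidin-1-yl at this carbon would separate the hydroxymethyl group from the saturated ring, and phenyl would do the same for the nitrogen of pyridin-4-yl, while a morpholine or a carboxylic acid there would show how far the read-out moves with other groups.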